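The compounds below may be only part of what the source reports. "The series", "measured", "known", "first", "only" and "open" are said of these compounds alone.

Working notes on the series around compound 1 `CCOC(=O)c1c(-c2cccc(OC)c2)[nH]c2cc(OC)ccc2c1=O`. In an ADME assay on HEK293 cells (Homo sapiens) for cytotoxicity, read by luminescence, with a stated time of 72 h (on this read-out higher numbers stand for an effect only at larger amounts of compound and lower numbers for an effect already at smaller amounts), compound 1 gives only the assay limit, > 22000 nM, and not a number. Compound 2 `CCOC(=O)c1c(-c2cccc(OCC(C)C)c2)[nH]c2cc(OC)ccc2c1=O` likewise returns the limit > 22000 nM. Compound 3 `CCOC(=O)c1c(-c2cccc(S(C)(=O)=O)c2)[nH]c2cc(OC)ccc2c1=O` also sits at the limit > 22000 nM. The steps among these three are therefore unreadable: a step that the two limits leave unreadable from compound 1 to compound 2, a step that the two limits leave unreadable from compound 1 to compound 3 and a step that the two limits leave unreadable from compound 2 to compound 3. What the three measurements do share is stated by the limit of > 22000 nM in this assay, at which 3 of the 3 values shown sit.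

Compound 4 `CCOC(=O)c1c(-c2cccc(CO)c2)[nH]c2cc(OC)ccc2c1=O` is not yet measured in this assay; it differs from compound 1 by hydroxymethyl in place of methoxy on an aromatic carbon. Within the data shown here, none of the measured steps has a readable size, so no direction of change beyond the scatter can be derived for the move from methoxy to hydroxymethyl on the aromatic carbon. Because every measured analogue rests at the limit of > 22000 nM in this assay, at which 3 of the 3 values shown sit, compound 4 is expected to do the same, and the step from compound 1 to compound 4 that this expectation means is a step that the limit leaves unreadable from compound 1 to compound 4. Compound 4 is thus estimated at 30000 nM, within a range of 15000 nM to 100000 nM.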

Compound 4, half-maximal effective concentration: > 22000 nM
Compound 4: only a limit was reported (the forecaster's own chance of this, stated with the estimate: 90%); the middle value lies beyond the limit too.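

In this assay compound 4 gives only a limit, > 22000 nM. Its steps to compound 1, compound 2 and compound 3 therefore cannot be read, and what the four share is: the limit of > 22000 nM in this assay, at which 4 of the 4 values shown sit.

The compounds shown leave open how far any of the four lies beyond that limit, and whether any change on the aromatic carbon would give a readable value in this assay.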